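The compounds below may be only part of what the source reports. "The series", "measured", "known", "first", "only" and "open" are said of these compounds alone.

Compound 1 `Fc1ccc(OC[C@@H]2CCN2)cn1` is the stronger of the two compounds measured in an assay on brain for binding affinity to Neuronal acetylcholine receptor; alpha4/beta2 (Rattus norvegicus), read by radioligand binding; a lower number here means a stronger inhibitor, a higher number a weaker inhibitor: compound 1 gives 0.057 nM, and compound 2 `N#Cc1ccc(OC[C@@H]2CCN2)cn1` gives 1.9 nM. For the measured compounds named here, the single measured step, a 33-fold higher number from compound 1 to compound 2 (1.52 log units; beyond the scatter), concerns the exchange of a cyano for a fluoro on an aromatic carbon and so says nothing about the configuration at the saturated ring.

Compound 3 `Fc1ccc(OC[C@H]2CCN2)cn1` is built from compound 1 by a change that touches no atom or bond: the two compounds have the same atoms and bonds and differ only in configuration as drawn: 1 of 1 stereo elements differ; a stereocentre at a saturated ring carbon is drawn S in compound 1 and R in compound 3. Going by the values given here, no measured pair differs in this way, so no step can be read across to it; the data give only the level of compound 1 as the starting point. The direction of the change in this assay is therefore open, and a loss cannot be excluded any more than a result within the scatter.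

Compound 3 is expected to fall at 2 nM, the estimate spanning from 0.1 nM to 30 nM. Against compound 1 this estimate means a step of a 35-fold higher number from compound 1 to compound 3 (1.55 log units; beyond the scatter), a weakening expected in the absence of any measured guide.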

Compound 3, inhibition constant: 0.066 nM
Compound 3: middle estimate off by 30-fold (1.48 log units), on the high side, outside the stated range (below it).
By their numbers in this assay, from the lowest: compounds 1 and 3 (each within the scatter of the next); then compound 2.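

In this assay, inverting the stereocentre at the saturated ring carbon, drawn S in compound 1 and R in compound 3, gives a 1.2-fold higher number from compound 1 to compound 3 (0.06 log units; within the scatter). For the compounds shown here, this is the first step that isolates this stereocentre, and its reading concerns configuration alone: the fact that compounds 1 and 3 differ only in the configuration as drawn. With the fluoro group in place, the two drawn configurations therefore cannot be told apart in this assay, while the only step beyond the scatter among the compounds shown remains the change on the aromatic carbon, a 33-fold higher number from compound 1 to compound 2 (1.52 log units; beyond the scatter).

The compounds shown leave open whether the same holds with the cyano group on the aromatic carbon, since compound 2 is shown with only one configuration at the saturated ring carbon, and so the indifference seen here belongs to the fluoro pair alone. They also leave open how other groups on that aromatic carbon, such as an amine, a carboxylic acid or a longer chain, would behave with either configuration, and whether the two configurations would still give matching values with any of them.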